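Swapping the sulfonyl aryl group for a dimethyl-oxazole

A few compounds are considered here, and "the series" means these few. Any claim that something is new, unique, unknown or untested is made for them only; others in the source may bear on it.

Two compounds have been measured in an assay on isolated protein for inhibition of RAC-alpha serine/threonine-protein kinase (Homo sapiens); a lower number here means a stronger inhibitor, a higher number a weaker inhibitor:

Compound 1, `Cc1cccc(C)c1S(=O)(=O)NC[C@@H](O)CN1CCC[C@@]2(CCN(c3ncnc(N)c3C3CC3)C2)C1`, gives 4 nM.
Compound 2, `Cc1cc(F)ccc1S(=O)(=O)NC[C@@H](O)CN1CCC[C@@]2(CCN(c3ncnc(N)c3C3CC3)C2)C1`, gives 8 nM.

Going by the values given here, compound 2 has the higher of these two numbers, but its only neighbour is compound 1, and the one measured step, a 2.0-fold higher number from compound 1 to compound 2 (0.30 log units; within the scatter), lies within the scatter of repeated measurements. So the two compounds cannot be told apart on the numbers shown, and compound 2 stands level with compound 1 rather than behind it.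

Compound 3, `Cc1noc(C)c1S(=O)(=O)NC[C@@H](O)CN1CCC[C@@]2(CCN(c3ncnc(N)c3C3CC3)C2)C1`, has not yet been measured. It differs from compound 2 in one place: 3,5-dimethyl-1,2-oxazol-4-yl in place of 4-fluoro-2-methylphenyl on a sulfonyl sulfur. Among the compounds with values here, the one measured step also exchanged the group on the sulfonyl sulfur, but it kept a six-membered aromatic ring of carbon only, whereas here a five-membered ring with two hetero atoms and two hydrogen-bond acceptors enters. That step offers only a weak guide, and it showed no change beyond the scatter. The expected step is a 1.9-fold higher number from compound 2 to compound 3 (0.27 log units; within the scatter), a small move towards a higher number that may still fall inside the scatter. In this assay compound 3 is estimated at 15 nM, with a range from 4 nM to 60 nM.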

Compound 3, half-maximal inhibitory concentration: 3 nM
Compound 3: middle estimate off by 5.0-fold (0.70 log units), on the high side; the measured number lies below the stated range.
By their numbers in this assay, from the lowest: compounds 3, 1 and 2 (each within the scatter of the next, the first and the last beyond it).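

In this assay, going by these compounds alone, the exchange of 4-fluoro-2-methylphenyl for 3,5-dimethyl-1,2-oxazol-4-yl on a sulfonyl sulfur gives a 2.7-fold lower number from compound 2 to compound 3 (0.43 log units; beyond the scatter) and is the first step at this position to lie beyond the scatter, so the position is not indifferent to the group it carries. The group on the sulfonyl sulfur also need not be a six-membered aromatic ring of carbon only: set against 2,6-dimethylphenyl, the five-membered ring with 2 hetero atoms gives a 1.3-fold lower number from compound 1 to compound 3 (0.12 log units; within the scatter) and so leaves compound 1 and compound 3 impossible to tell apart on these numbers. No measurement among the data shown accounts for the step from compound 2 to compound 3.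

The compounds shown leave open whether a 1,2-oxazole without its two methyl groups, or a pyrazole or a pyridine in its place, would keep a number like that of compound 3 in this assay as well. They also leave open how far this ring would tolerate a larger substituent, such as an amine or a carboxylic acid in place of a methyl group.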